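Replacing the Last Chlorine with Hydroxy on the Hydrazone Ring

This account rests on a few compounds, and the source may have more. Where it says the series, first, only, none or still open, it means among the compounds named here.

Measured compounds:
Compound 1 `CN(C)CCn1cnnc1-c1cc(Oc2ccc(NC(=O)N/N=C/c3cccc(Cl)c3Cl)cc2F)ccn1`: 130 nM
Compound 2 `CN(C)CCn1cnnc1-c1cc(Oc2ccc(NC(=O)N/N=C/c3ccc(Cl)cc3)cc2F)ccn1`: 530 nM

Both numbers come from a functional assay on HT-29 cells (Homo sapiens) for cytotoxicity, read by MTT assay, with a stated time of 72 h; a higher number here means a weaker inhibitor, a lower number a stronger inhibitor. Compound 2 stands at the highest of the two numbers; its nearest neighbour is compound 1, and a 4.1-fold higher number from compound 1 to compound 2 (0.61 log units; beyond the scatter) separates them beyond the scatter, a step that went with the loss of one chlorine from the same ring. The unmeasured compound 3 `CN(C)CCn1cnnc1-c1cc(Oc2ccc(NC(=O)N/N=C/c3ccc(O)cc3)cc2F)ccn1` differs from compound 2 in one place: hydroxy in place of chloro on an aromatic carbon. Among the measured compounds shown here, no measured step swaps chloro for hydroxy, so the only guidance is that the one earlier change on this ring, removing chlorine, gave a higher number. Compound 3 is therefore expected to give 1200 nM in this assay, with a likely range from 300 nM to 5000 nM. This amounts to an expected 2.3-fold higher number from compound 2 to compound 3 (0.35 log units; beyond the scatter), with considerable uncertainty in either direction.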

Compound 3, half-maximal inhibitory concentration: 1920 nM
The estimate for compound 3 lay 1.6-fold (0.20 log units) below the measured number, and the stated range covers the measured number.
By their numbers in this assay, from the lowest: compound 1; then compound 2; then compound 3.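

In this assay, hydroxy in place of chloro on this ring gives a 3.6-fold higher number from compound 2 to compound 3 (0.56 log units; beyond the scatter), so the chloro group cannot be exchanged for hydroxy here without a measurable loss, and compound 3 is the weakest of the three. Measured against the 2,3-dichlorophenyl of compound 1, the 4-hydroxyphenyl ring gives a 15-fold higher number from compound 1 to compound 3 (1.17 log units; beyond the scatter), a large step, and each single change on this ring so far has gone with a higher number, with no compound shown going against that. Nothing at hand explains the rise, which comes with the hydroxy group's added hydrogen-bond donor but cannot be tied to it.

As far as these compounds go, whether a methoxy group or an amine at this place would behave more like chloro or more like hydroxy stays open. So does whether the 2,3-dichloro arrangement would keep its lower number with hydroxy on the same ring.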